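From anilino to (1,3-thiazol-2-yl)amino on a shared core

The compounds below may be only part of what the source reports. "The series", "measured", "known", "first", "only" and "open" are said of these compounds alone.

Measured in a functional assay on SK-MEL-28 cells (Homo sapiens) for cytotoxicity, read by MTT assay, with a stated time of 3 days; a lower number here means a stronger inhibitor, a higher number a weaker inhibitor
Compound 1 `N#Cc1c(O)nc(SCc2nc3ccccc3[nH]2)nc1-c1ccccc1` gives 7.7 nM
Compound 2 `N#Cc1c(Cl)nc(SCc2nc3ccccc3[nH]2)nc1-c1ccccc1` gives 3.28 nM
Compound 3 `N#Cc1c(Nc2ccccc2)nc(SCc2nc3ccccc3[nH]2)nc1-c1ccccc1` gives 8.9 nM

In this assay compound 3 stands level with compound 1 (a 1.2-fold higher number from compound 1 to compound 3 (0.06 log units; within the scatter)) but apart from compound 2 (a 2.7-fold higher number from compound 2 to compound 3 (0.43 log units; beyond the scatter)). The next compound, compound 4 `N#Cc1c(Nc2nccs2)nc(SCc2nc3ccccc3[nH]2)nc1-c1ccccc1`, keeps the shared core and alters only the ring on the nitrogen (1,3-thiazol-2-yl in place of phenyl on a nitrogen on an aromatic ring). In words, this is 1,3-thiazol-2-yl in place of phenyl on a nitrogen on an aromatic ring.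

For the measured compounds named here, no measured pair makes this exact swap, so the evidence is indirect. The nearest guides are the two steps that bring in the anilino group, and both replace a whole group on an aromatic carbon. One stayed within the scatter and the other was only modest, as was the remaining step (a 2.3-fold lower number from compound 1 to compound 2 (0.37 log units; beyond the scatter)). The new change is narrower than those, since the nitrogen stays and only its ring is exchanged. With just three compounds, the data point in no clear direction, so no step beyond the scatter is expected.

The expected step is a 1.3-fold lower number from compound 3 to compound 4 (0.10 log units; within the scatter) and it should stay small. The estimate for compound 4 is 7 nM, with an expected range from 2.5 nM to 20 nM.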

Compound 4, half-maximal inhibitory concentration: 8.9 nM
Beside the measured number, compound 4's estimate is 1.3-fold (0.10 log units) below it; measured number inside the range.
By their numbers in this assay, from the lowest: compound 2; then compounds 1, 3 and 4 (each within the scatter of the next).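

In this assay, for the compounds shown here, exchanging the phenyl on the nitrogen for 1,3-thiazol-2-yl gives the first direct reading of a change to this ring alone (no change at the digits printed from compound 3 to compound 4 (within the scatter)). A six-membered aromatic ring of carbon only and a five-membered aromatic ring with 2 hetero atoms therefore cannot be told apart at this position, at least for this pair. The new group also matches the pattern set by anilino against the earlier groups, sitting level with hydroxy (a 1.2-fold higher number from compound 1 to compound 4 (0.06 log units; within the scatter)) and apart from chloro (a 2.7-fold higher number from compound 2 to compound 4 (0.43 log units; beyond the scatter)), so among these four compounds only compound 2 stands apart from the others. Nothing available explains why the ring exchange leaves the number unchanged.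

As far as these compounds go, it remains open whether any ring is needed on this nitrogen at all, since a plain amino group or a longer chain such as hexyl would test that directly. From the compounds shown here alone, it is also open whether the lower number of compound 2 is particular to chloro, which a fluoro or methoxy group on the same aromatic carbon would help to settle.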